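Replacing 2-Fluorophenyl in Compound 2

A few compounds are considered here, and "the series" means these few. Any claim that something is new, unique, unknown or untested is made for them only; others in the source may bear on it.

In a functional assay on HepG2 cells (Homo sapiens) for cytotoxicity, read by MTT assay, with a stated time of 24 h (on this read-out higher numbers stand for weaker inhibition and lower numbers for stronger inhibition), compound 1 `CN1C/C(=C\c2ccc(C(F)(F)F)cc2)C(=O)/C(=C/c2ccccc2F)C1` gives 4140 nM, while compound 2 `CN1C/C(=C\c2ccc(C#N)cc2)C(=O)/C(=C/c2ccccc2F)C1` gives 590 nM, the lower of the two numbers. For the measured compounds named here, the only measured step, a 7.0-fold lower number from compound 1 to compound 2 (0.85 log units; beyond the scatter), is cyano in place of trifluoromethyl on an aromatic carbon. Compound 3 `CN1C/C(=C\c2ccc(Cl)cc2)C(=O)/C(=C/c2ccc(C#N)cc2)C1` instead carries 4-chlorophenyl in place of 2-fluorophenyl on a double-bonded chain carbon bound to a double-bonded ring carbon. The measured step leaves the 2-fluorophenyl group untouched and gives no direction for this change, so no shift beyond the scatter is expected. The estimated step is a 1.4-fold higher number from compound 2 to compound 3 (0.13 log units; within the scatter). For compound 3, the expected value is 800 nM, with an estimated range of 250 nM to 2600 nM.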

Compound 3, half-maximal inhibitory concentration: 5950 nM
Compound 3: the middle estimate sits 7.4-fold (0.87 log units) below what was measured, outside the stated range (above it).
By their numbers in this assay, from the lowest: compound 2; then compounds 1 and 3 (each within the scatter of the next).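

In this assay, the earlier step changed only the other aromatic group, whereas this one shows that the position on a double-bonded chain carbon bound to a double-bonded ring carbon also moves the number. Here, 4-chlorophenyl in place of 2-fluorophenyl gives a 10-fold higher number from compound 2 to compound 3 (1.00 log units; beyond the scatter), so this change is not neutral in this setting. No available evidence explains the shift.

On these data alone, what 4-fluorophenyl or 2-chlorophenyl would give at this position remains open, and with it whether the halogen or its place on the ring accounts for the step. As far as these compounds go, how a phenyl bearing an amine or a carboxylic acid would read here also remains open.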